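The source may hold more compounds than are shown below. What is called first, only, known or untested is meant among the compounds shown, and "the series" means these compounds.

Measured compounds in a functional assay on KYSE-510 cells (Homo sapiens) for antiproliferative activity, read by crystal violet staining, with a stated time of 96 h; on this read-out higher numbers stand for weaker inhibition of growth and lower numbers for stronger inhibition of growth:

- Compound 1 `COc1cc(C)ccc1S(=O)(=O)NC1=NCCN1C(=S)SN1CCn2c1nsc2=S`; in this assay compound 1 gives >= 20000 nM, a limit of the assay.
- Compound 2 `COc1cccc(S(=O)(=O)NC2=NCCN2C(=S)SN2CCn3c2nsc3=S)c1`; in this assay compound 2 gives >= 20000 nM, a limit of the assay.
- Compound 3 `COc1ccc(S(=O)(=O)NC2=NCCN2C(=S)SN2CCn3c2nsc3=S)cc1`; in this assay compound 3 gives >= 20000 nM, a limit of the assay.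

Compound 3 therefore stands nowhere on a scale of numbers: its value is a limit only, and the two other values shown are limits of the same kind (the limit of >= 20000 nM in this assay, at which 3 of the 3 values shown sit). The three measured steps that share the shared core and the sulfonyl sulfur bring no readable size: a step that the two limits leave unreadable from compound 1 to compound 2, a step that the two limits leave unreadable from compound 1 to compound 3 and a step that the two limits leave unreadable from compound 2 to compound 3 all sit between two limits.

Compound 4 `O=[N+]([O-])c1ccc(S(=O)(=O)NC2=NCCN2C(=S)SN2CCn3c2nsc3=S)cc1` differs from compound 3 by nitro in place of methoxy on an aromatic carbon. For the measured compounds named here, none of the measured steps bears on this change with a readable size; the only thing they show is that three different substitution patterns of the aromatic ring on the sulfonyl sulfur all left the compounds at the limit. Without a single readable step, no direction can be expected for a number no higher from compound 3 to compound 4 (the limit leaves the size open), and a step beyond the scatter cannot be predicted.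

Compound 4 is thus expected to give about 20000 nM in this assay, within an estimated range from 8000 nM to 50000 nM, and most likely to be reported as a limit again.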

Compound 4, concentration for 50% growth inhibition: >= 20000 nM
Compound 4 ended at the assay's limit (the forecaster's own chance of this, stated with the estimate: 75%); the middle value lies on the limit itself.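

No new step can be read in this assay: compound 4 sits at the same limit of the assay as compound 1, compound 2 and compound 3, so all its steps run between two limits: the limit of >= 20000 nM in this assay, at which 4 of the 4 values shown sit.

The compounds shown leave open how far any of the four lies beyond that limit, and whether the aromatic group on the sulfonyl sulfur affects growth inhibition at all.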